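Furan-3-yl replacing 3-nitrophenyl: half-life outlook

This account rests on a few compounds, and the source may have more. Where it says the series, first, only, none or still open, it means among the compounds named here.

Among the compounds with values here, compound 3 `O=C1O[C@@H](Cn2ccnn2)CN1c1ccc(N2CCN(Cc3cccc([N+](=O)[O-])c3)CC2)c(F)c1` gives 5.34 h in an in vivo ADME assay on the whole organism (strain Sprague-Dawley) for metabolic stability, with Rattus norvegicus as the target, at a dose of 50 mg/kg by the oral route (a lower number here means that the compound disappears faster, a higher number that the compound lasts longer), the highest of the three numbers so far. Compound 1 `Nc1ccc(CN2CCN(c3ccc(N4C[C@H](Cn5ccnn5)OC4=O)cc3F)CC2)cc1` gives 4.67 h, and the step of a 1.1-fold higher number from compound 1 to compound 3 (0.06 log units; within the scatter) lies within the scatter, so these two are not ordered against each other. Compound 2 `O=C1O[C@@H](Cn2ccnn2)CN1c1ccc(N2CCN(Cc3ccc([N+](=O)[O-])o3)CC2)c(F)c1` gives 1.66 h; the step of a 3.2-fold higher number from compound 2 to compound 3 (0.51 log units; beyond the scatter) is beyond the scatter, as is a 2.8-fold lower number from compound 1 to compound 2 (0.45 log units; beyond the scatter).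

Compound 4 `O=C1O[C@@H](Cn2ccnn2)CN1c1ccc(N2CCN(Cc3ccoc3)CC2)c(F)c1` differs from compound 3 by furan-3-yl in place of 3-nitrophenyl on a saturated chain carbon bound to an amine nitrogen in a ring. Within the data shown here, no measured step places a furan-3-yl on this carbon. Among the measured compounds the only five-membered aromatic ring with one oxygen is the 5-nitrofuran-2-yl of compound 2, which carries the lowest number, and both steps into and out of it were modest. The exchange of 4-aminophenyl for 3-nitrophenyl, by contrast, changed little. Compound 2 is therefore only a partial guide, since the entering furan-3-yl carries no nitro and is a different furan isomer.

On balance a modest decrease is expected, a 1.8-fold lower number from compound 3 to compound 4 (0.25 log units; within the scatter), with a wide allowance for the gap in the evidence. In this assay compound 4 is expected to give 3 h, in a range from 1.5 h to 6 h.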

Compound 4, half-life: 8.6 h
Compound 4: middle estimate off by 2.9-fold (0.46 log units), on the low side; the measured number lies above the stated range.
By their numbers in this assay, from the lowest: compound 2; then compounds 1, 3 and 4 (each within the scatter of the next).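

In this assay the step of a 1.6-fold higher number from compound 3 to compound 4 (0.21 log units; within the scatter) lies within the scatter, as does a 1.8-fold higher number from compound 1 to compound 4 (0.27 log units; within the scatter), so compounds 1, 3 and 4 are not ordered against each other, and on this saturated chain carbon furan-3-yl, with 5 heavy atoms and no nitro group, sits in the same band as the 9-atom 3-nitrophenyl and as 4-aminophenyl. The step of a 5.2-fold higher number from compound 2 to compound 4 (0.71 log units; beyond the scatter) lies beyond the scatter, which shows that a furan ring on this carbon does not by itself bring the low number of compound 2; among the listed compounds that low number goes with 5-nitrofuran-2-yl alone. No measurement on hand gives a reason for any of these steps.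

Furan-3-yl and 5-nitrofuran-2-yl differ both in the nitro group and in the furan isomer, so the step between them cannot say which of the two carries the difference; plain furan-2-yl would separate them. As far as these compounds go, it also remains open whether unsubstituted phenyl, thiophen-3-yl or saturated tetrahydrofuran-3-yl on this carbon would fall in the same band.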